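The source may hold more compounds than are shown below. What is called first, only, known or untested is meant among the compounds shown, and "the series" means these compounds.

The measured compounds:
Compound 1, `COC(=O)/C=C/c1cccc(NC(=O)C2CCCCC2)c1`, reads > 1000 nM in an assay on isolated protein with Bile acid receptor (Homo sapiens) as the target (on this read-out lower numbers stand for an effect already at smaller amounts and higher numbers for an effect only at larger amounts of compound), which is a limit of the assay and not a number.
Compound 2, `COC(=O)/C=C/c1cccc(N(Cc2ccccc2Br)C(=O)C2CCCCC2)c1`, reads > 1000 nM in this assay, again a limit rather than a number.

Compound 2 therefore stands at the limit, and so does every other value shown (the limit of > 1000 nM in this assay, at which 2 of the 2 values shown sit). Within the data shown here, the only measured step, a step that the two limits leave unreadable from compound 1 to compound 2, runs between two limits, so its size cannot be read. Compound 3, `COC(=O)/C=C/c1cccc(N(Cc2cccc(Br)c2)C(=O)C2CCCCC2)c1`, differs from compound 2 in one place: 3-bromophenyl in place of 2-bromophenyl on a saturated chain carbon bound to an amide-type nitrogen. Among the measured compounds shown here, no measured step bears directly on this change, and the step into compound 2 gives no readable size to lean on. Compound 3 is therefore expected to sit at or near the limit as well. The expected step that the limit leaves unreadable from compound 2 to compound 3 means no movement beyond the scatter. The estimate for compound 3 in this assay is 3000 nM, with a range from 800 nM to 30000 nM.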

Compound 3, half-maximal effective concentration: > 1000 nM
Compound 3: only a limit was reported; the forecaster's own chance of this, stated with the estimate: 80%; the middle value does not contradict the limit.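

No step can be read among compound 1, compound 2 and compound 3, since each value is a limit and not a number: the limit of > 1000 nM in this assay, at which 3 of the 3 values shown sit. Still open, on these data alone, is how far 2-bromobenzyl and 3-bromobenzyl differ in this assay, and at what amount, if any, these compounds reach a half-maximal effect.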